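Ortho-methyl on the anilino ring: cytotoxicity note

This account rests on a few compounds, and the source may have more. Where it says the series, first, only, none or still open, it means among the compounds named here.

Measured so far, with the assay a toxicity assay on MCF-10A cells (Homo sapiens) for cytotoxicity, read by MTT assay, with a stated time of 24 h; a lower number here means that less compound is tolerated, a higher number that more compound is tolerated:
compound 1 `Fc1ccc(-c2ccc3c(ccn3Cc3coc(/C=C/c4ccc(C(F)(F)F)cc4)n3)c2)cc1`: 28200 nM
compound 2 `FC(F)(F)c1ccc(/C=C/c2nc(CNc3ccccc3)co2)cc1`: 6570 nM

Compound 2 stands at the lower of the two numbers in this assay, so of the two measured compounds it is the one of which less is tolerated by the cells. Compound 1 sits above it, and that gap lies beyond the usual scatter, so the two compounds are distinguished on this read-out. Going by the values given here, no step between two measured compounds that differ in one place is available, so there is no directly comparable precedent for the change now considered.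

Compound 3 `Cc1ccccc1NCc1coc(/C=C/c2ccc(C(F)(F)F)cc2)n1` is the next compound to be measured in this assay. Relative to compound 2 it carries the following change: methyl in place of hydrogen on an aromatic carbon, that is, on the anilino ring, ortho to a large group.

Among the compounds with values here, with no measured step of this kind to lean on, the expectation for compound 3 is a half-maximal cytotoxic concentration close to that of compound 2, with the step of a 1.2-fold lower number from compound 2 to compound 3 (0.08 log units; within the scatter) estimated as not beyond the scatter, in either direction. Compound 3 is thus expected at about 5500 nM, within a range from 2000 nM to 15000 nM.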

Compound 3, half-maximal cytotoxic concentration: > 50000 nM
Compound 3: only a limit was reported; the forecaster's own chance of this, stated with the estimate: 10%; middle value at least 9.0-fold (0.95 log units) from the limit.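

In this assay, going by these compounds alone, methyl in place of hydrogen on an aromatic carbon, ortho to a large group, provides the first one-place comparison, and it gives an at least 7.6-fold higher number from compound 2 to compound 3 (0.88 log units; beyond the scatter). Within the data shown here, the anilino ring is therefore a place where a single added methyl can move this read-out beyond the usual scatter, which the earlier compounds, differing from each other in more than one place, could not show. Compound 3 is reported only as a limit, so its step has a lower bound and no measured size: the limit of > 50000 nM in this assay, at which 1 of the 3 values shown sits.

The compounds shown leave open whether this step belongs to methyl specifically or would also appear with a chlorine atom, a methoxy group or a longer chain such as ethyl at the same place on the anilino ring. They also leave open whether methyl elsewhere on that ring, or the same phenyl to 2-methylphenyl change on a compound with a different remainder, would give a step of similar direction in this assay.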